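Phenyl in Place of Methyl on a Ring Nitrogen

A few compounds are considered here, and "the series" means these few. Any claim that something is new, unique, unknown or untested is made for them only; others in the source may bear on it.

Of the compounds shown here, two have so far been measured in a functional assay on THP-1 cells (Homo sapiens) for inhibition, read by ELISA, tested at 10 uM; on this read-out lower numbers stand for less inhibition and higher numbers for more inhibition at the one concentration tested (going by the name of the read-out). Compound 1 `Cc1nn(C)c2ncc(CCCO)cc12` gives 27% in this assay. Compound 2 `COC[C@H](O)[C@@H](OC)[C@@H](OC)c1cnc2cc(-c3ccc(C)cc3)nn2c1`, built on a different core, gives 34% in this assay; the two numbers lie within the scatter of each other, so nothing separates them. Among the compounds with values here, no pair of measured compounds differs in a single place, so no measured change serves as a yardstick.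

Compound 3 `Cc1nn(-c2ccccc2)c2ncc(CCCO)cc12` is compound 1 with phenyl in place of methyl on an aromatic nitrogen. The phenyl enters on an aromatic nitrogen of a five-membered aromatic ring with 2 nitrogen, part of a fused system of two rings. Within the data shown here, with no measured step to lean on, the expected step from compound 1 to compound 3 is modest and toward more inhibition, estimated as a number 8 percentage points higher from compound 1 to compound 3 (within the scatter). Compound 3 is accordingly expected to give 35% in this assay, within an estimated range from 10% to 65%.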

Compound 3, a percentage reported as inhibition, at one concentration (the size of the read-out at that concentration, not a potency): 19%
Compound 3: the middle estimate sits 16 percentage points above what was measured; the measured number falls inside the stated range.
By their numbers in this assay, from the lowest: compounds 3, 1 and 2 (each within the scatter of the next, the first and the last beyond it).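

In this assay, within the data shown here, phenyl in place of methyl on the aromatic nitrogen comes out as a number 8 percentage points lower from compound 1 to compound 3 (within the scatter), the first step here between compounds that differ in one place. It shows that a six-membered aromatic ring of carbon only can stand on this nitrogen in place of a methyl without the inhibition at the one concentration tested leaving the scatter of compound 1. Nothing at hand bears on why the number comes out this way.

Going by these compounds, what a longer alkyl chain, a benzyl group or an amine-bearing chain would do on this same nitrogen remains open. Also open is how the read-out would answer a change at the ring atom that bears a methyl group, since the compounds shown vary only the group on the nitrogen.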